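The compounds below may be only part of what the source reports. "The series", "measured", "known", "first", "only" and "open" are said of these compounds alone.

Measured so far:
- compound 1, `O=C(Nc1cccc(I)c1)C(Cl)Cl`: in a functional assay on BGC-823 cells (Homo sapiens) for antiproliferative activity, read by MTT assay, with a stated time of 72 h (a lower number here means a stronger inhibitor, a higher number a weaker inhibitor), compound 1 gives 58800 nM.
- compound 2, `N#Cc1cccc(NC(=O)C(Cl)Cl)c1`: in this assay compound 2 gives "not determined" (no result reported).

Among the compounds with values here, all three compounds share the same core, a dichloroacetamide attached to a benzene ring, and differ only in the single group carried on that ring. Compound 1 carries iodine and is a weak inhibitor in this assay. Within the data shown here, compound 2 carries a cyano group; for it no number was obtained, so it cannot be placed on the scale at all, and no step from compound 1 to compound 2 can be stated.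

Compound 3, `O=C(Nc1cccc([N+](=O)[O-])c1)C(Cl)Cl`, is the next member. The change from compound 2 to compound 3 is nitro in place of cyano on an aromatic carbon. With no measured value for compound 2, no step size can be computed, and the only anchor is the weak result of compound 1 in this assay.

On that anchor alone, compound 3 is expected to remain a weak inhibitor, with an estimated value of 50000 nM and a likely range from 15000 nM to 200000 nM.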

Compound 3, half-maximal inhibitory concentration: 123000 nM
Estimate against measurement, compound 3: 2.5-fold (0.39 log units) below; the measured number falls inside the stated range.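

In this assay, putting nitro in place of iodo on this aromatic carbon gives a 2.1-fold higher number from compound 1 to compound 3 (0.32 log units; beyond the scatter), a modest step but one beyond the usual scatter, so the group at this place does change the read-out, and of the two measured groups, nitro gives the weaker inhibitor. On these data alone, compound 2 has no number, so the change from cyano to nitro cannot be read, and the nitrile's place in this comparison remains unknown. Nothing measured here explains why the nitro compound gives the higher number.

The compounds shown leave open whether another group at this place, such as an amine, a carboxylic acid or a longer chain like propyl, would move the number further, and in which direction. Within the data shown here, with only two measured values, they also cannot show whether any pattern runs across groups at this position, or whether any group here can turn this weakly active series into a strong inhibitor.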